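Methyl in Place of Fluoro: Expecting Compound 4

The source may hold more compounds than are shown below. What is called first, only, known or untested is meant among the compounds shown, and "the series" means these compounds.

Compound 1 `Cc1ccc(S(=O)(=O)Oc2ccc3c(c2C)[C@H](Cn2cc(-c4ccc(Br)cc4)nn2)[C@@]24CC(=O)[C@@](C)(CC[C@@H]32)C4)cc1` in a functional assay on SMMC-7721 cells (Homo sapiens) for cytotoxicity, read by MTT assay, with a stated time of 4 days (a lower number here means a stronger inhibitor, a higher number a weaker inhibitor), gives > 20000 nM, a limit of the assay, not a number.
Compound 2 `Cc1ccc(-c2cn(C[C@H]3c4c(ccc(O)c4C)[C@@H]4CC[C@@]5(C)C[C@]43CC5=O)nn2)cc1` gives > 20000 nM, also a limit.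
Compound 3 `Cc1ccc(S(=O)(=O)Oc2ccc3c(c2C)[C@H](Cn2cc(-c4ccc(F)cc4)nn2)[C@@]24CC(=O)[C@@](C)(CC[C@@H]32)C4)cc1` gives > 20000 nM, again a limit.

Compound 3 therefore stands at the limit, as do both other measured compounds: the limit of > 20000 nM in this assay, at which 3 of the 3 values shown sit. For the measured compounds named here, the only single change measured, a step that the two limits leave unreadable from compound 1 to compound 3, cannot be read because both ends are limits. Compound 4 `Cc1ccc(-c2cn(C[C@H]3c4c(ccc(OS(=O)(=O)c5ccc(C)cc5)c4C)[C@@H]4CC[C@@]5(C)C[C@]43CC5=O)nn2)cc1` differs from compound 3 by methyl in place of fluoro on an aromatic carbon. Going by the values given here, no measured step tests methyl in place of fluoro, and no readable step exists at all, so no direction can be taken from the data. Compound 4 is expected to remain at the limit as well, the estimated step being a step that the limit leaves unreadable from compound 3 to compound 4. The estimated value of compound 4 is 40000 nM, within 15000 nM to 150000 nM.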

Compound 4, half-maximal inhibitory concentration: > 20000 nM
Compound 4 was reported as a limit (the forecaster's own chance of this, stated with the estimate: 85%); the middle value lies beyond the limit too.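

No new step can be read between compound 4 and compound 1, compound 2 or compound 3, because all four results are limits and not numbers: the limit of > 20000 nM in this assay, at which 4 of the 4 values shown sit.

On these data alone, whether any of these changes affects potency in this assay remains open.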